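A few compounds are considered here, and "the series" means these few. Any claim that something is new, unique, unknown or untested is made for them only; others in the source may bear on it.

Working notes on the series.

Compound 1 `Cc1ccsc1CN[C@@H]1C[C@H]2C[C@@H]([C@H]1C)C2(C)C` sits second highest of the three numbers in hand: in an ADME assay on MDCK cells (Canis lupus familiaris) for cytotoxicity, read by microscopy, with a stated time of 48 h (on this read-out higher numbers stand for lower toxicity in this test and lower numbers for higher toxicity in this test), compound 1 gives 10000 nM. Its nearest neighbour is compound 3 `C[C@H]1[C@H](NCc2ccco2)C[C@H]2C[C@@H]1C2(C)C`, which in this assay gives 50000 nM, the step being a 5.0-fold higher number from compound 1 to compound 3 (0.70 log units; beyond the scatter). Furthest away is compound 2 `Cc1ccc(CN[C@@H]2C[C@H]3C[C@@H]([C@H]2C)C3(C)C)s1`, which in this assay gives 780 nM, the step being a 13-fold lower number from compound 1 to compound 2 (1.11 log units; beyond the scatter); between the two the gap is a 64-fold higher number from compound 2 to compound 3 (1.81 log units; beyond the scatter).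

Compound 4 `C[C@H]1[C@H](NCc2sccc2-c2ccsc2)C[C@H]2C[C@@H]1C2(C)C` differs from compound 1 by thiophen-3-yl in place of methyl on an aromatic carbon. Among the measured compounds shown here, no measured step swaps a methyl for a second ring; the closest guides are the changes of the aromatic group itself, which moved the number by a 13-fold lower number from compound 1 to compound 2 (1.11 log units; beyond the scatter) and a 5.0-fold higher number from compound 1 to compound 3 (0.70 log units; beyond the scatter), so the aryl part clearly matters beyond the scatter, with no consistent direction across the three. A whole ring entering is a larger change than either, and on balance a lower number is expected for compound 4, roughly a 5.0-fold lower number from compound 1 to compound 4 (0.70 log units; beyond the scatter). Compound 4 is therefore estimated at 2000 nM, within 300 nM to 12000 nM.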

Compound 4, minimum cytotoxic concentration: 12500 nM
Compound 4: middle estimate off by 6.3-fold (0.80 log units), on the low side; measured number above the stated range.
By their numbers in this assay, from the lowest: compound 2; then compounds 1 and 4 (each within the scatter of the next); then compound 3.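

On an aromatic carbon two ring bonds from the ring sulfur, thiophen-3-yl in place of methyl gives a 1.3-fold higher number from compound 1 to compound 4 (0.10 log units; within the scatter) in this assay. Among the compounds shown here, this is the first change at this position, and a whole five-membered aromatic ring can enter there with compounds 1 and 4 lying within the scatter of each other. The two earlier changes of the aromatic group, a 13-fold lower number from compound 1 to compound 2 (1.11 log units; beyond the scatter) and a 5.0-fold higher number from compound 1 to compound 3 (0.70 log units; beyond the scatter), both lie beyond the scatter, so in this small set the size of the incoming group does not by itself set the size of the step. Nothing measured here accounts for this result.

Open, as far as these compounds go, is whether an amine, a carboxylic acid or a longer chain on this aromatic carbon would also stay within the scatter of compound 1. Also open, from the compounds shown here alone, is whether a phenyl ring there would do the same.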